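Compound 4: replacing dipropylamino with pyrrolidin-1-yl

This account rests on a few compounds, and the source may have more. Where it says the series, first, only, none or still open, it means among the compounds named here.

- Compound 1 `CCc1cc(CC)n2nc(-c3ccc(OC)cc3)c(CC(=O)N(C)C)c2n1`: 2.47
- Compound 2 `CCCN(CCC)C(=O)Cc1c(-c2ccc(OC)cc2)nn2c(CC)cc(CC)nc12`: 3.35
- Compound 3 `CCc1cc(CC)n2nc(-c3ccc(OC)cc3)c(CC(=O)N(C(C)CC)C(C)CC)c2n1`: 3.75

In a physicochemical assay for lipophilicity, read by HPLC, at pH 7.5 (on this read-out lower numbers stand for lower lipophilicity and higher numbers for higher lipophilicity), compound 2 stands second highest of the three, below compound 3 and above compound 1. Compound 4 `CCc1cc(CC)n2nc(-c3ccc(OC)cc3)c(CC(=O)N3CCCC3)c2n1` differs from compound 2 in one place, with pyrrolidin-1-yl in place of dipropylamino on a carbonyl carbon. Three measured steps change this same group: a number 0.88 log units higher from compound 1 to compound 2 (beyond the scatter), a number 1.28 log units higher from compound 1 to compound 3 (beyond the scatter) and a number 0.40 log units higher from compound 2 to compound 3 (beyond the scatter). Among these three compounds, the value rises from dimethylamino through dipropylamino to bis(sec-butyl)amino. Pyrrolidin-1-yl has fewer heavy atoms than dipropylamino, so a modest fall that undoes much of a number 0.88 log units higher from compound 1 to compound 2 (beyond the scatter) is expected in this assay. The expected step is a number 0.60 log units lower from compound 2 to compound 4 (beyond the scatter). The estimate for compound 4 is 2.75, with an expected range of 2.45 to 3.05.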

Compound 4, partition coefficient: 2.72
Compound 4: the middle estimate sits 0.03 log units above what was measured, within the range that was stated.
By their numbers in this assay, from the lowest: compounds 1 and 4 (each within the scatter of the next); then compound 2; then compound 3.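

Pyrrolidin-1-yl puts a ring on this carbonyl carbon for the first time, and a number 0.63 log units lower from compound 2 to compound 4 (beyond the scatter) and a number 1.03 log units lower from compound 3 to compound 4 (beyond the scatter) are seen in this assay when it enters. Against dimethylamino the step is a number 0.25 log units higher from compound 1 to compound 4 (within the scatter) and gives no order between the two, so this ring reads with dimethylamino rather than with dipropylamino. Nothing measured here gives a reason for this result. On these data alone, whether piperidin-1-yl, a larger ring, or morpholin-4-yl, a ring holding an oxygen, would read the same way stays open.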